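This account rests on a few compounds, and the source may have more. Where it says the series, first, only, none or still open, it means among the compounds named here.

Measured compounds:
compound 1 `C/C(C(=O)NC1CC1)=C(/C)c1ccc(Br)cc1`, 600 mg/kg
compound 2 `C/C(C(=O)NC1CC1)=C(/C)c1ccc(F)cc1`, 200 mg/kg
compound 3 `C#CCNC(=O)/C(C)=C(\C)c1ccccc1`, 400 mg/kg

All three compounds were tested in a toxicity assay on the whole organism (strain Icem-CET (SPF Caw)) for cytotoxicity, with Mus musculus as the target; a lower number here means that less compound is needed, a higher number that more compound is needed for the effect. Compound 3 stands in the middle of the three numbers: its value in this assay is separated from that of compound 1 and from that of compound 2 only by gaps that lie within the usual scatter, so no order among these three can be read from the numbers.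

Compound 4 `C/C(C(=O)NC1CC1)=C(/C)c1ccccc1` has not yet been measured. It differs from compound 3 in one place: cyclopropyl in place of propargyl on an amide-type nitrogen. Within the data shown here, the one measured step, a 3.0-fold lower number from compound 1 to compound 2 (0.48 log units; beyond the scatter), concerns a halogen on the aromatic ring and not the amide nitrogen, so it does not bear directly on the change from compound 3 to compound 4. Among the measured compounds shown here, the only guide is that compounds 1 and 2, which already carry the cyclopropyl amide, give values lying around that of compound 3, and their gaps to compound 3 are within the scatter.

Compound 4 is therefore expected to show no step beyond the scatter in this assay, that is no change at the digits printed from compound 3 to compound 4 (within the scatter). The estimate for compound 4 is 400 mg/kg, with a range from 200 mg/kg to 800 mg/kg.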

Compound 4, dose for half-maximal effect: 250 mg/kg
Estimate against measurement, compound 4: 1.6-fold (0.20 log units) above; measured number inside the range.
By their numbers in this assay, from the lowest: compounds 2, 4, 3 and 1 (each within the scatter of the next, the first and the last beyond it).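

In this assay, cyclopropyl in place of propargyl on the amide-type nitrogen gives (a 1.6-fold lower number from compound 3 to compound 4 (0.20 log units; within the scatter)), so this first look at that position cannot tell apart two groups of equal heavy-atom count, one with a triple bond and one with a three-membered ring. Compound 4 also provides the hydrogen partner for both halogen compounds, and this separates them: hydrogen in place of fluoro on an aromatic carbon gives (a 1.3-fold higher number from compound 2 to compound 4 (0.10 log units; within the scatter)), while hydrogen in place of bromo gives (a 2.4-fold lower number from compound 1 to compound 4 (0.38 log units; beyond the scatter)), so among these compounds only bromo stands apart from hydrogen, and only modestly. No measurement is available that would explain where any of these numbers fall. 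

The compounds shown leave open whether the amide-type nitrogen stays this indifferent to groups of another kind, such as a longer carbon chain or a chain ending in a carboxylic acid. They also leave open whether bromo on the aromatic ring would matter in the same way with propargyl on the nitrogen, since both halogens appear here only with cyclopropyl.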